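Compound 1 to compound 4: a sulfonamide ring change

This account rests on a few compounds, and the source may have more. Where it says the series, first, only, none or still open, it means among the compounds named here.

Measured so far in a functional assay on SF-295 cells (Homo sapiens) for antiproliferative activity, read by sulforhodamine B assay, with a stated time of 72 h; a lower number here means a stronger inhibitor, a higher number a weaker inhibitor
- compound 1 `Cc1cc(C)nc(NS(=O)(=O)c2ccc(Nc3nncc4ccccc34)cc2)n1` gives 0.56 nM
- compound 2 `S=C(NNc1nncc2ccccc12)Nc1ccccc1` gives 9.5 nM
- compound 3 `O=C1CS/C(=N/Nc2nncc3ccccc23)N1` gives 2.4 nM

Compound 1 has the lowest number of the three, beyond the scatter from both compound 3 and compound 2. Compound 4 `Cc1cc(NS(=O)(=O)c2ccc(Nc3nncc4ccccc34)cc2)no1` is not yet measured. It differs from compound 1 by one change 5-methyl-1,2-oxazol-3-yl in place of 4,6-dimethylpyrimidin-2-yl on a sulfonamide nitrogen with 5-methyl-1,2-oxazol-3-yl in place of 4,6-dimethylpyrimidin-2-yl on a sulfonamide nitrogen. Among the measured compounds shown here, no measured pair isolates a change at this place, so the expectation is tentative. With compound 1 at 0.56 nM as the low end of the values, a modest rise in this assay is more likely than a fall. The expected step is a 2.1-fold higher number from compound 1 to compound 4 (0.33 log units; beyond the scatter) at about the edge of the scatter. Compound 4 is estimated at 1.2 nM with 0.4 nM to 4 nM as the expected range.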

Compound 4, half-maximal inhibitory concentration: 4.4 nM
The estimate for compound 4 lay 3.7-fold (0.56 log units) below the measured number; measured number above the stated range.
By their numbers in this assay, from the lowest: compound 1; then compounds 3 and 4 (each within the scatter of the next); then compound 2.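

In this assay, among the compounds shown here, the change to 5-methyl-1,2-oxazol-3-yl in place of 4,6-dimethylpyrimidin-2-yl on the sulfonamide nitrogen gives a 7.9-fold higher number from compound 1 to compound 4 (0.90 log units; beyond the scatter) and is the only step read at this place. The position is therefore sensitive to which ring it carries, although both groups have the same counts of hydrogen-bond donors and acceptors. No data here bear on the cause of the step.
This single step changes ring size and hetero atoms together, leaving their separate contributions open. From the compounds shown here alone, how a phenyl ring or a pyridin-2-yl group on the same nitrogen would compare also remains open.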